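The compounds below may be only part of what the source reports. "The series", "measured", "known", "first", "only" and "open" are said of these compounds alone.

Measured in an ADME assay on microsomes from liver (Homo sapiens) for metabolic stability, read by LC-MS, with a stated time of 30 min, tested at 0.1 uM; a lower number here means that less of the compound is left, a higher number that more of the compound is left:
- Compound 1 `COc1ccnc(Nc2cc3[nH]c(-c4cccc(C(F)(F)F)c4)nc3cn2)c1`: 80%
- Compound 2 `FC(F)(F)c1cccc(-c2nc3cnc(Nc4cccnn4)cc3[nH]2)c1`: 84%
- Compound 3 `N#Cc1ccc(Nc2cc3[nH]c(-c4cccc(C(F)(F)F)c4)nc3cn2)nc1`: 39%

Compound 1 belongs to the upper pair of these three numbers. The data show a number 4 percentage points higher from compound 1 to compound 2 (within the scatter), and they also show a number 41 percentage points lower from compound 1 to compound 3 (beyond the scatter).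

Compound 4 `FC(F)(F)c1ccc(Nc2cc3[nH]c(-c4cccc(C(F)(F)F)c4)nc3cn2)nc1` has not yet been measured. It carries 5-(trifluoromethyl)pyridin-2-yl in place of 4-methoxypyridin-2-yl on a nitrogen on an aromatic ring.

Within the data shown here, three measured steps bear on this change. Among the measured compounds shown here, the closest precedent is compound 3, whose 5-cyanopyridin-2-yl is the only measured group that, like the entering group, is a pyridin-2-yl with its substituent named at the 5 position. Replacing the group of compound 1 with it gave a number 41 percentage points lower from compound 1 to compound 3 (beyond the scatter), and the comparison from the other side gave a number 45 percentage points lower from compound 2 to compound 3 (beyond the scatter). Not every replacement moves the number, however, as compound 2 shows with a number 4 percentage points higher from compound 1 to compound 2 (within the scatter). For the measured compounds named here, no measured compound carries the trifluoromethyl group on this pyridine, so the precedent of compound 3 may transfer only in part.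

A large fall in this assay is therefore expected, though with considerable uncertainty. The expected step is a number 32 percentage points lower from compound 1 to compound 4 (beyond the scatter). For compound 4 the estimated value is 48%, with an expected range from 27% to 72%.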

Compound 4, percent of the compound remaining: 90%
Beside the measured number, compound 4's estimate is 42 percentage points below it, outside the stated range (above it).
By their numbers in this assay, from the lowest: compound 3; then compounds 1, 2 and 4 (each within the scatter of the next).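

In this assay the large fall seen with compound 3 does not extend to every pyridin-2-yl group on this nitrogen: trifluoromethyl in place of cyano on an aromatic carbon gives a number 51 percentage points higher from compound 3 to compound 4 (beyond the scatter) as a large step from a change in one substituent. Against the two other groups on the nitrogen, the new group shows a number 10 percentage points higher from compound 1 to compound 4 (within the scatter) and a number 6 percentage points higher from compound 2 to compound 4 (within the scatter) with both steps inside the scatter. Among these four compounds the low number therefore goes with the 5-cyanopyridin-2-yl of compound 3 alone, while compound 1, compound 2 and compound 4 carry three different groups at this place and cannot be told apart. Nothing available here accounts for the wide gap between the cyano and trifluoromethyl compounds.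

As far as these compounds go, it stays open whether an amine or a carboxylic acid in place of the trifluoromethyl on the pyridin-2-yl would follow compound 4 or compound 3. The compounds shown also all keep the same 3-(trifluoromethyl)phenyl group on the shared core, so they leave open whether the gap between cyano and trifluoromethyl would persist with a different group there, such as a morpholine.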